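Ester chain variation on a shared core, antiproliferative read-out

A few compounds are considered here, and "the series" means these few. Any claim that something is new, unique, unknown or untested is made for them only; others in the source may bear on it.

Compound 1 `C/C=C1/[C@H](O[C@@H]2O[C@H](CO)[C@@H](O)[C@H](O)[C@H]2O)OC=C(C(=O)OC)[C@H]1CC(=O)OCc1ccco1`, > 15000 nM in a functional assay on SK-BR-3 cells (Homo sapiens) for antiproliferative activity, read by MTT assay, with a stated time of 72 h; on this read-out lower numbers stand for stronger inhibition and higher numbers for weaker inhibition
Compound 2 `C/C=C1/[C@H](O[C@@H]2O[C@H](CO)[C@@H](O)[C@H](O)[C@H]2O)OC=C(C(=O)OC)[C@H]1CC(=O)OCCc1ccc2c(c1)OCCO2`, > 20000 nM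
Compound 3 `C/C=C1/[C@H](O[C@@H]2O[C@H](CO)[C@@H](O)[C@H](O)[C@H]2O)OC=C(C(=O)OC)[C@H]1CC(=O)OC`, > 15000 nM

Compound 3 stands only at a limit of this assay, not at a number. Compound 1 likewise sits at a limit (the limit of > 15000 nM in this assay, at which 2 of the 3 values shown sit). Compound 2 sits at a limit (the limit of > 20000 nM in this assay, at which 1 of the 3 values shown sits). The measured steps, a step that the two limits leave unreadable from compound 1 to compound 2, a step that the two limits leave unreadable from compound 1 to compound 3 and a step that the two limits leave unreadable from compound 2 to compound 3, are all unreadable between limits.

Compound 4 `C/C=C1/[C@H](O[C@@H]2O[C@H](CO)[C@@H](O)[C@H](O)[C@H]2O)OC=C(C(=O)OC)[C@H]1CC(=O)OCC` differs from compound 3 by methyl in place of hydrogen on a saturated chain carbon bound to an oxygen next to a carbonyl group. The steps into and out of compound 3 change the same position but give no readable size, so no direction can be drawn. Compound 4 is expected to remain at a limit, with a step that the limit leaves unreadable from compound 3 to compound 4 unreadable. Compound 4 is estimated at 30000 nM, between 10000 nM and 100000 nM.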

Compound 4, half-maximal inhibitory concentration: > 15000 nM
Compound 4: a limit, no number; the forecaster's own chance of this, stated with the estimate: 85%; the middle value is on the limit's open side.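

Among these compounds, compound 4, at > 15000 nM, stands at a limit, so no step to compound 4 from compound 1, compound 2 or compound 3 can be read. The compounds shown leave open whether any ester chain on the shared core gives a measurable value.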